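The source may hold more compounds than are shown below. What is called first, only, known or untested is meant among the compounds shown, and "the series" means these compounds.

Measured so far:
compound 1 `O=C(Nc1ccc2nc(NC(=O)C3CCCCC3)sc2c1)c1cccnc1Cl` — 0.075 ug/mL
compound 2 `CC(=O)Nc1nc2ccc(NC(=O)c3c(Cl)cccc3Cl)cc2s1` — 0.6 ug/mL

In a functional assay on WI-38 VA13 cells (Homo sapiens) for cytotoxicity (a higher number here means that more compound is needed for the effect, a lower number that less compound is needed), compound 2 gives 0.6 ug/mL, the highest of the two numbers; compound 1 comes out with the lower figure, and the gap between them lies beyond the scatter. The two differ in more than one place, so nothing measured isolates what any single change does.

Compound 3 `O=C(NCc1ccccc1)Nc1nc2ccc(NC(=O)c3c(Cl)cccc3Cl)cc2s1` has not yet been measured. It keeps the whole of compound 2 except at one point: benzylamino in place of methyl on a carbonyl carbon. For the measured compounds named here, no pair with a single difference has been run, so this replacement is untested.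

The expectation for compound 3 in this assay therefore rests on the two values alone and is held loosely. Compound 1, with its larger amide partner, shows 0.075 ug/mL, but its other parts differ as well, so only a modest step toward a lower number is expected, roughly at the edge of the scatter. The step from compound 2 to compound 3 is estimated at a 2.0-fold lower number from compound 2 to compound 3 (0.30 log units; within the scatter). Compound 3 is expected near 0.3 ug/mL, with a range from 0.08 ug/mL to 1.2 ug/mL.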

Compound 3, half-maximal effective concentration: 0.15 ug/mL
The estimate for compound 3 lay 2.0-fold (0.30 log units) above the measured number; measured number inside the range.
By their numbers in this assay, from the lowest: compounds 1 and 3 (each within the scatter of the next); then compound 2.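

In this assay, for the compounds shown here, the carbonyl carbon on the amide-type nitrogen of compound 2 proves open to far more than methyl: benzylamino there gives a 4.0-fold lower number from compound 2 to compound 3 (0.60 log units; beyond the scatter), the first step that can be read as a single replacement. The position is therefore not limited to the acetyl of compound 2, since the change of acetyl to benzylcarbamoyl, which brings an aromatic ring and a hydrogen-bond donor, moves the number down and not up. Nothing on hand accounts for this step, and the entering group brings its nitrogen and its ring in one replacement, so the share of each cannot be told apart.

A methylamino group on the same carbonyl carbon would test the nitrogen without the ring, while a benzyl group would test the ring without the nitrogen. A phenethylamino group, with its longer chain, would show whether the distance from the carbonyl to the aromatic ring matters, and a single step is too little to say whether any trend holds at this position.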